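A cyclopropyl group added to compound 3

The source may report more compounds than this note shows. Statements on the series, on what has been measured and on what is new or still open speak of the compounds shown alone.

Values so far in an ADME assay on Caco-2 cells (Homo sapiens) for permeability, read by LC-MS, in the apical to basolateral direction, with a stated time of 2 h (on this read-out lower numbers stand for lower permeability and higher numbers for higher permeability), for three compounds
Compound 1 `COc1cc(C(=O)N2CCCC2(C)C)cc2nc(NCc3cccc(Cl)c3)oc12` reads "not determined" (no result reported)
Compound 2 `COc1cc(C(=O)N2CC[C@@H](O)C(C)(C)C2)cc2nc(NCc3cccc(Cl)c3)oc12` reads "not determined" (no result reported)
Compound 3 `COc1cc(C(=O)N2CCC(O)C(C)C2)cc2nc(NCc3cccc(Cl)c3)oc12` reads 84 nm/s

Compound 3 is the only one of the three with a number, so it cannot yet be called high or low against the others. Within the data shown here, compound 1 and compound 2 share its core but have no result, which leaves no measured step to learn from.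

The next compound, compound 4 `COc1cc(C(=O)N2CC(C)C(O)CC2C2CC2)cc2nc(NCc3cccc(Cl)c3)oc12`, keeps that core and alters only the ring on the amide. The 4-hydroxy-3-methylpiperidin-1-yl group becomes 2-cyclopropyl-4-hydroxy-5-methylpiperidin-1-yl. The change reads cyclopropyl in place of hydrogen on a saturated ring carbon and amounts to cyclopropyl in place of hydrogen on a saturated ring carbon.

Among the measured compounds shown here, nothing measured so far shows how such a change plays out in this assay and the only anchor is compound 3 at 84 nm/s as a starting point. The expected change is therefore modest, with a 1.1-fold higher number from compound 3 to compound 4 (0.03 log units; within the scatter) estimated to stay within the usual scatter and no firm direction. For compound 4 the estimated value is 90 nm/s with an expected range from 35 nm/s to 220 nm/s in this measurement.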

Compound 4, apparent permeability: 138 nm/s
Beside the measured number, compound 4's estimate is 1.5-fold (0.19 log units) below it; measured number inside the range.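

In this assay, putting a cyclopropyl group in place of hydrogen on a saturated ring carbon, next to the ring nitrogen, gives a 1.6-fold higher number from compound 3 to compound 4 (0.22 log units; within the scatter), so this first measured pair on the amide ring shows no separation between the two compounds on this read-out. Among these compounds, until now there was only a single number with nothing to set it against, whereas this pair shows that a new three-membered ring at this position, two ring bonds from the ring atom that bears the hydroxy group, still leaves the reading within the normal spread of repeat measurements. No independent measurement is available to explain why the reading behaves this way.

From the compounds shown here alone, one pair at one position says little about other substituents, so it remains open whether a methyl group, a phenyl ring or an aminomethyl group on the same ring carbon would also read like compound 3. Going by these compounds, it is equally open whether the cyclopropyl group would give a similar reading on another ring carbon, or on a ring with the hydroxy group replaced by a methoxy group.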